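The compounds below may be only part of what the source reports. "The series", "measured", "known", "first", "only" and "open" are said of these compounds alone.

Measured compounds in an ADME assay on MDBK cells (Bos taurus) for cytotoxicity, read by MTT assay, with a stated time of 96 h; a higher number here means that more compound is tolerated, a lower number that less compound is tolerated
- compound 1 `FC(F)(F)c1cccc(NC(=S)Nc2ccc(I)cc2)c1` gives 9500 nM
- compound 2 `FC(F)(F)c1cccc(NC(=S)Nc2cccc(Br)c2)c1` gives 10000 nM

Compound 1 (9500 nM) has only compound 2 (10000 nM) as a neighbour, and the two cannot be told apart. Going by the values given here, the single measured step is small (a 1.1-fold higher number from compound 1 to compound 2 (0.02 log units; within the scatter)), and it exchanges one halogen-bearing aryl group for another.

Compound 3 `CCOC(=O)c1ccc(NC(=S)Nc2cccc(C(F)(F)F)c2)cc1` has not been measured. It differs from compound 1 as follows: ethoxycarbonyl in place of iodo on an aromatic carbon (ethoxycarbonyl in place of iodo on an aromatic carbon, para to a large group). Among the compounds with values here, no measured compound carries ethoxycarbonyl, so the series offers no direct precedent for this change, and the one step available bears on it only loosely. Within the data shown here, with that limitation, no step beyond the scatter is expected in this assay, since the only measured change gave a 1.1-fold higher number from compound 1 to compound 2 (0.02 log units; within the scatter) and nothing yet points in either direction. The estimated move is small (a 1.3-fold higher number from compound 1 to compound 3 (0.10 log units; within the scatter)). Among the measured compounds shown here, the range is kept wide because only two values support it, compound 1 at 9500 nM and compound 2 at 10000 nM. The expected value for compound 3 is 12000 nM (estimated range 4500 nM to 35000 nM).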

Compound 3, half-maximal cytotoxic concentration: 64000 nM
The estimate for compound 3 lay 5.3-fold (0.73 log units) below the measured number; the measured number lies above the stated range.
By their numbers in this assay, from the lowest: compounds 1 and 2 (each within the scatter of the next); then compound 3.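

In this assay, going by these compounds alone, ethoxycarbonyl in place of iodo on an aromatic carbon, para to a large group, gives a 6.7-fold higher number from compound 1 to compound 3 (0.83 log units; beyond the scatter), whereas the only earlier step, a 1.1-fold higher number from compound 1 to compound 2 (0.02 log units; within the scatter), showed no separable change between two halogen-bearing aryl groups. This position therefore does respond to what it carries, at least for this exchange, and the tolerated concentration moves upward with the ester. The change replaces iodo, with 1 heavy atom and 0 hydrogen-bond acceptors, by a group with 5 heavy atoms, 2 hydrogen-bond acceptors and a double bond outside aromatic rings, so several features change at once in a single step, and nothing available accounts for the size of that step.

Still open, as far as these compounds go, is whether the higher number belongs to the ester as such or would also appear with a carboxylic acid, a nitrile or a methoxy group on the same aromatic carbon. A methyl ester or a longer alkyl ester in place of ethoxycarbonyl would show whether the length of the chain matters.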